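This account rests on a few compounds, and the source may have more. Where it says the series, first, only, none or still open, it means among the compounds named here.

Measured so far in a physicochemical assay for acid dissociation: compound 1 `COc1cccc(CNCCCNc2ccnc3cc(-c4ccc(C(C)(C)C)cc4)ccc23)c1O` gives 9.47; compound 2 `COc1cccc(CNCCCNc2ccnc3cc(CC(C)C)ccc23)c1O` gives 9.47.

Compound 2 stands level with compound 1 at the digits printed: the step of no change at the digits printed from compound 1 to compound 2 (within the scatter) is no change within the scatter, so exchanging the aromatic substituent on the fused ring of the shared core for a small alkyl chain left the acid dissociation constant where it was. Compound 2 is therefore neither higher nor lower than compound 1 on the numbers shown.

Compound 3 `COc1ccccc1Oc1ccc2c(NCCCNCc3cccc(OC)c3O)ccnc2c1` remains to be measured in this assay. It differs from compound 2 in one place: 2-methoxyphenoxy in place of isobutyl on an aromatic carbon. For the measured compounds named here, the only measured step that bears on this position is the one from compound 1 to compound 2, which was within the scatter, and the group that enters and the group that leaves both sit at the same aromatic carbon of the shared core, away from the ionizable centres. The expected step of no change at the digits printed from compound 2 to compound 3 (within the scatter) is therefore none beyond the scatter. For compound 3 the estimate in this assay is 9.47, with a range from 9.1 to 9.8.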

Compound 3, acid dissociation constant: 9.28
Compound 3: the middle estimate sits 0.19 log units above what was measured; the measured number falls inside the stated range.
By their numbers in this assay, from the lowest: compounds 3, 1 and 2 (each within the scatter of the next).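

In this assay, 2-methoxyphenoxy in place of isobutyl gives a number 0.19 log units lower from compound 2 to compound 3 (within the scatter), and the same group in place of 4-(tert-butyl)phenyl gives a number 0.19 log units lower from compound 1 to compound 3 (within the scatter). For the compounds shown here, the earlier pair compared only two groups made of carbon alone, whereas this change brings oxygen and hydrogen-bond acceptors to the same aromatic carbon, and the three compounds still cannot be told apart in this assay, so across these three groups the read-out does not follow the exchange at this position. Nothing in hand explains this outcome or says which proton the read-out reports.

On these data alone, all three groups at this aromatic carbon carry no net charge, so whether an amine or a carboxylic acid there would move the number beyond the scatter stays open. The compounds shown also vary in this one place only, which leaves open how this assay would respond to a change elsewhere on the shared core, such as a longer chain in the linker.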